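Chain length on the thioether and MOLT-3 inhibition

The compounds below may be only part of what the source reports. "The series", "measured", "known", "first", "only" and "open" are said of these compounds alone.

The series keeps one core and varies the alkyl chain on the thioether. Compound 1 `CCCCSC[C@H](NC(C)=O)C(=O)CCl` carries a butyl chain and in a functional assay on MOLT-3 cells (Homo sapiens) (on this read-out lower numbers stand for stronger inhibition and higher numbers for weaker inhibition), compound 1 gives 5600 nM. Compound 2 `CCCCCCSC[C@H](NC(C)=O)C(=O)CCl` carries a hexyl chain, and in this assay compound 2 gives 700 nM. Compound 3 `CCCCCCCCCCSC[C@H](NC(C)=O)C(=O)CCl` carries a decyl chain, and in this assay compound 3 gives 3400 nM, the second highest number of the three: its gap to compound 1 is within the scatter, while a 4.9-fold higher number from compound 2 to compound 3 (0.69 log units; beyond the scatter) is beyond it. Compound 4 `CCCCCCCCCCCSC[C@H](NC(C)=O)C(=O)CCl` is the next member: methyl in place of hydrogen on a saturated chain carbon, ten or more bonds along the chain from a sulfur, so the chain grows by one carbon at its far end.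

Among the compounds with values here, two measured steps bear on this change. Lengthening the chain gave an 8.0-fold lower number from compound 1 to compound 2 (0.90 log units; beyond the scatter), but lengthening it further gave a 4.9-fold higher number from compound 2 to compound 3 (0.69 log units; beyond the scatter), so beyond hexyl the trend turns. A single extra carbon on an already long chain is a small change set against those, and in this assay compound 4 is expected to sit close to compound 3, with a 1.2-fold higher number from compound 3 to compound 4 (0.09 log units; within the scatter) as the likely outcome, if anything a slightly higher number. The estimate for compound 4 is 4200 nM, within 1800 nM to 10000 nM.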

Compound 4, half-maximal inhibitory concentration: 3000 nM
For compound 4 the middle estimate is 1.4-fold (0.15 log units) above the measured one; the range from low to high includes it.
By their numbers in this assay, from the lowest: compound 2; then compounds 4, 3 and 1 (each within the scatter of the next).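

In this assay, methyl in place of hydrogen on a saturated chain carbon leaves compound 4 level with the decyl chain of compound 3 (a 1.1-fold lower number from compound 3 to compound 4 (0.05 log units; within the scatter)), so at this far end of the chain a single extra carbon does not separate the two. The loss against the hexyl chain also holds for a second long chain (a 4.3-fold higher number from compound 2 to compound 4 (0.63 log units; beyond the scatter)), which means the turn no longer rests on compound 3 alone, and compound 2 stays the strongest of the four. The long chain of compound 4 also cannot be told apart from the butyl chain of compound 1 (a 1.9-fold lower number from compound 1 to compound 4 (0.27 log units; within the scatter)), so among these four compounds only the hexyl chain stands clear of the others, and none of the four goes against that. No measurement at hand speaks to what lies behind this profile.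

A heptyl or octyl chain would show whether the lowest number sits at hexyl or somewhat further out. Also open, on these data alone, is how the hexyl chain responds to an amine or a carboxylic acid at its far end.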